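The compounds below may be only part of what the source reports. "The series", "measured", "known", "first", "only" and "open" are said of these compounds alone.

Of the compounds shown here, three built on a shared core have been tested in a functional assay on SK-MEL-5 cells (Homo sapiens) for inhibition, read by sulforhodamine B assay, with a stated time of 48 h; a lower number here means a stronger inhibitor of growth, a higher number a weaker inhibitor of growth. Compound 1 `COc1ccc(C(=O)/C=C/c2cc(-c3cc(OC)c(OC)c(OC)c3)n[nH]2)cc1OC` gives 1650 nM. Compound 2 `COc1ccc(C(=O)/C=C/c2cc(-c3cc(OC)c(OC)c(OC)c3)n[nH]2)cc1` gives 1720 nM. Compound 3 `COc1cc(-c2cc(/C=C/C(=O)c3ccc(F)c(F)c3)[nH]n2)cc(OC)c1OC` gives 2270 nM. Compound 1 has the lowest number of the three, but the step of a 1.0-fold higher number from compound 1 to compound 2 (0.02 log units; within the scatter) and the step of a 1.4-fold higher number from compound 1 to compound 3 (0.14 log units; within the scatter) both lie within the scatter, so no ranking among them can be drawn.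

Compound 4 `COc1cc(C(=O)/C=C/c2cc(-c3cc(OC)c(OC)c(OC)c3)n[nH]2)cc(OC)c1OC` has not yet been measured. It differs from compound 1 in one place: methoxy in place of hydrogen on an aromatic carbon.

The measured steps all concern the same aryl ring attached to the carbonyl. Removing a methoxy there, as in the step from compound 1 to compound 2, changed nothing beyond the scatter, and exchanging the whole ring for a 3,4-difluorophenyl, as in the step of a 1.3-fold higher number from compound 2 to compound 3 (0.12 log units; within the scatter), also stayed within the scatter. Adding a third methoxy to that ring is therefore expected to leave the number where it is, and the estimated step of a 1.0-fold higher number from compound 1 to compound 4 (0.01 log units; within the scatter) is expected to fall within the scatter. For compound 4 the estimate in this assay is 1700 nM, with a range from 800 nM to 3600 nM.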

Compound 4, concentration for 50% growth inhibition: 1570 nM
Compound 4: the middle estimate sits 1.1-fold (0.03 log units) above what was measured, and the stated range covers the measured number.
By their numbers in this assay, from the lowest: compounds 4, 1, 2 and 3 (each within the scatter of the next).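

The earlier steps shown here removed a methoxy from the ring attached to the carbonyl or replaced that ring whole. Here a methoxy enters that ring on an aromatic carbon, ortho to a methoxy group and meta to a large group, and this assay records a 1.1-fold lower number from compound 1 to compound 4 (0.02 log units; within the scatter), so adding this group brings no change that can be read. Set beside a 1.0-fold higher number from compound 1 to compound 2 (0.02 log units; within the scatter), this shows that both removing one methoxy from compound 1 and adding another leave the number within the scatter, so neither change on this ring gives a readable difference in this assay. No measurement here bears on why the added methoxy leaves the number in place.

From the compounds shown here alone, it remains open whether a different group on this same aromatic carbon, such as a hydroxyl, an amine, a carboxylic acid or a longer chain like ethoxy, would also stay within the scatter. Going by these compounds, the other aryl ring carries the same three methoxy groups in all four compounds, so what happens when those groups change also remains open.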